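The compounds below may be only part of what the source reports. "The series", "measured", "known", "first", "only" and "open" are said of these compounds alone.

Compound 1, `C=CC(=O)N1CC[C@H](N2C(=O)N(c3ccccc3)Cc3cnc(Nc4cccc(N5CCN(C)CC5)c4)nc32)C1`: 540 nM
Compound 2, `C=CC(=O)N1CC[C@H](N2C(=O)N(c3ccccc3)Cc3cnc(Nc4ccc(N5CCN(C)CC5)cc4OC)nc32)C1`: 1080 nM
Compound 3, `C=CC(=O)N1CC[C@H](N2C(=O)N(c3ccccc3)Cc3cnc(Nc4ccc(N5CCN(C)CC5)c(OC)c4)nc32)C1`: 739 nM

These three values all come from an ADME assay on the whole organism (strain Sprague-Dawley) for pharmacokinetics, with Rattus norvegicus as the target, read by LC-MS, at a dose of 25 mg/kg by the oral route; a higher number here means more compound in the circulation at the dose given, a lower number less compound in the circulation. Compound 3 gives the middle value of the three, yet its gaps to compound 1 and to compound 2 are both within the usual scatter of repeated runs, so the three compounds cannot be told apart on these numbers. Compound 4, `C=CC(=O)N1CC[C@H](N2C(=O)N(c3ccccc3)Cc3cnc(Nc4ccc(N5CCN(C)CC5)c(C)c4)nc32)C1`, has not been measured. It differs from compound 3 in one place: methyl in place of methoxy on an aromatic carbon. Among the compounds with values here, no pair of measured compounds shows this change, so there is nothing to say how it shifts the value. For compound 4 the expected step of a 1.1-fold lower number from compound 3 to compound 4 (0.06 log units; within the scatter) is estimated to stay within the scatter, with no direction favoured. In this assay compound 4 is therefore expected to give about 650 nM, in a range from 250 nM to 1700 nM.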

Compound 4, maximal plasma concentration: 1880 nM
Estimate against measurement, compound 4: 2.9-fold (0.46 log units) below, and the stated range ends below it.
By their numbers in this assay, from the lowest: compounds 1, 3, 2 and 4 (each within the scatter of the next, the first and the last beyond it).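

On an aromatic carbon ortho to a 4-methylpiperazin-1-yl group, methyl in place of methoxy gives a 2.5-fold higher number from compound 3 to compound 4 (0.41 log units; beyond the scatter) in this assay. Within the data shown here, this is the first single change to be read directly, and it shows that this one position can shift the number beyond the scatter. Nothing measured here accounts for the rise. 

This rests on a single pair of compounds. As far as these compounds go, whether an ethyl group, a chlorine atom or an amine at this position would give a similar number remains open.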